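Benzamide Substituent Change: Vinyl Replaced by Cyano

The source may hold more compounds than are shown below. What is called first, only, known or untested is meant among the compounds shown, and "the series" means these compounds.

Compound 2 `C=Cc1cccc(C(=O)NCN2CCC(c3cccc[n+]3[O-])CC2)c1` carries the vinyl group that sets it apart from compound 1 `O=C(NCN1CCC(c2cccc[n+]2[O-])CC1)c1ccccc1`. In a functional assay on HEK293 cells for agonist activity at D(4) dopamine receptor (Homo sapiens), read by FLIPR (a lower number here means that less compound is needed, a higher number that more compound is needed for the effect), compound 2 gives 68 nM, the lowest of the two numbers recorded, and compound 1 gives 532 nM. Within the data shown here, the only measured step, a 7.8-fold lower number from compound 1 to compound 2 (0.89 log units; beyond the scatter), adds vinyl on an aromatic carbon. Compound 3 `N#Cc1cccc(C(=O)NCN2CCC(c3cccc[n+]3[O-])CC2)c1` takes the change (cyano in place of vinyl on an aromatic carbon), on an aromatic carbon of the six-membered ring of carbon only, meta to a large group. Among the measured compounds shown here, no measured step swaps one substituent for another at that carbon; the direction is open. A number between those of compound 1 and compound 2 is expected, a 2.2-fold higher number from compound 2 to compound 3 (0.34 log units; beyond the scatter). For compound 3 in this assay the estimate is 150 nM, within 40 nM to 600 nM.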

Compound 3, half-maximal effective concentration: 840 nM
For compound 3 the middle estimate is 5.6-fold (0.75 log units) below the measured one; the measured number lies above the stated range.
By their numbers in this assay, from the lowest: compound 2; then compounds 1 and 3 (each within the scatter of the next).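

In this assay, the benefit of vinyl at this aromatic carbon does not carry over to cyano, a group with the same heavy-atom count (a 12-fold higher number from compound 2 to compound 3 (1.09 log units; beyond the scatter)). Compared with the unsubstituted compound, cyano gives no separation beyond the scatter (a 1.6-fold higher number from compound 1 to compound 3 (0.20 log units; within the scatter)), so among these three compounds only vinyl changes the number at this carbon. No evidence at hand bears on the difference between the two groups. From the compounds shown here alone, whether an ethyl group, a methoxy group or an amine at this carbon would track vinyl or cyano remains open.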